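Acylsulfonamide series: phenyl for methyl on the sulfonyl

A few compounds are considered here, and "the series" means these few. Any claim that something is new, unique, unknown or untested is made for them only; others in the source may bear on it.

Measured so far:
compound 1 `COCC(=O)Nc1ccc2c(cnn2CC(=O)COc2ccc(Oc3ccccc3)cc2)c1` — 6300 nM
compound 2 `CS(=O)(=O)NC(=O)c1ccc2c(cnn2CC(=O)COc2ccc(Oc3ccccc3)cc2)c1` — 770 nM

In an assay on microsomes from brain for inhibition of Fatty-acid amide hydrolase 1 (Rattus norvegicus), read by fluorescence and HPLC, with a stated time of 45 min (a higher number here means a weaker inhibitor, a lower number a stronger inhibitor), compound 1 gives 6300 nM, while compound 2 gives 770 nM. For the measured compounds named here, the single measured step is an 8.2-fold lower number from compound 1 to compound 2 (0.91 log units; beyond the scatter), and on these two numbers compound 2 stands as the lower one, with compound 1 the only neighbour.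

Compound 3 `O=C(COc1ccc(Oc2ccccc2)cc1)Cn1ncc2cc(C(=O)NS(=O)(=O)c3ccccc3)ccc21` differs from compound 2 by phenyl in place of methyl on a sulfonyl sulfur. Going by the values given here, the one step on record, an 8.2-fold lower number from compound 1 to compound 2 (0.91 log units; beyond the scatter), exchanges the whole group on the aromatic carbon and says nothing about what sits on the sulfonyl sulfur, so no measured step bears directly on this change. Among the compounds with values here, with no guiding step, the expected change is a 1.3-fold lower number from compound 2 to compound 3 (0.11 log units; within the scatter), that is within the scatter or at most modest, direction open. Compound 3 is therefore estimated at 600 nM, range 150 nM to 2500 nM.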

Compound 3, half-maximal inhibitory concentration: 4700 nM
Beside the measured number, compound 3's estimate is 7.8-fold (0.89 log units) below it; measured number outside the range, above it.
By their numbers in this assay, from the lowest: compound 2; then compounds 3 and 1 (each within the scatter of the next).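

In this assay the group on the sulfonyl sulfur is not a free choice: phenyl in place of methyl gives a 6.1-fold higher number from compound 2 to compound 3 (0.79 log units; beyond the scatter), so the result for the (methylsulfonyl)carbamoyl group does not carry over to the (phenylsulfonyl)carbamoyl group. The step from the ((methoxymethyl)carbonyl)amino group to the (phenylsulfonyl)carbamoyl group reads a 1.3-fold lower number from compound 1 to compound 3 (0.13 log units; within the scatter), whereas the methyl member gave an 8.2-fold lower number from compound 1 to compound 2 (0.91 log units; beyond the scatter), so the lower number belongs to the methylsulfonyl version alone among these compounds and not to both sulfonyl groups. Nothing on hand explains this difference.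

The compounds shown leave open whether an ethyl group or a cyclopropyl ring on the sulfonyl sulfur reads closer to compound 2 or to compound 3. Also open, on these data alone, is how a carboxylic acid on the same aromatic carbon would read in place of the whole (methylsulfonyl)carbamoyl group.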